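This account rests on a few compounds, and the source may have more. Where it says the series, first, only, none or still open, it means among the compounds named here.

Compound 3 `CCCCC1CCC(OC(=O)N[C@@H](CC(C)C)C(=O)N[C@@H](C[C@@H]2CCNC2=O)C(O)S(=O)(=O)O)CC1` is one of three compounds tested in a toxicity assay on L929 cells (Mus musculus) for cytotoxicity (on this read-out higher numbers stand for lower toxicity in this test and lower numbers for higher toxicity in this test), where compound 3 gives 59100 nM. Compound 1 `CCCCC1CCC(OC(=O)N[C@@H](CC(C)C)C(=O)N[C@H](C=O)C[C@@H]2CCNC2=O)CC1` gives 63300 nM, and the step of a 1.1-fold lower number from compound 1 to compound 3 (0.03 log units; within the scatter) shows that compound 3 and compound 1 lie within the scatter of each other. Compound 2 `CC(C)C[C@H](NC(=O)OC1CCC(F)(F)CC1)C(=O)N[C@H](C=O)C[C@@H]1CCNC1=O` reaches only a limit of the assay, > 100000 nM. Compound 4 `CC(C)C[C@H](NC(=O)OC1CCC(F)(F)CC1)C(=O)N[C@@H](C[C@@H]1CCNC1=O)C(O)S(=O)(=O)O` is not yet measured; it differs from compound 3 by a group of 8 heavy atoms (6 carbon, 2 fluorine; one six-membered non-aromatic ring of carbon only) in place of a group of 10 heavy atoms (10 carbon; one six-membered non-aromatic ring of carbon only), on an oxygen next to a carbonyl group. The same exchange has been seen once already, as an at least 1.5-fold higher number from compound 1 to compound 2 (0.19 log units; that floor lies within the scatter), a step whose true size is hidden because it ends at the limit of > 100000 nM in this assay, at which 1 of the 3 values shown sits. On that basis compound 4 is expected to show a 2.0-fold higher number from compound 3 to compound 4 (0.31 log units; beyond the scatter), a higher number and thus lower toxicity. The estimate for compound 4 is 120000 nM, between 60000 nM and 300000 nM.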

Compound 4, half-maximal cytotoxic concentration: > 100000 nM
Compound 4: no number, only a limit; the forecaster's own chance of this, stated with the estimate: 60%; the middle value is on the limit's open side.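

In this assay, the exchange to 4,4-difluorocyclohexyl on an oxygen next to a carbonyl group gives an at least 1.6-fold higher number from compound 3 to compound 4 (0.22 log units; that floor lies within the scatter), so on the core carrying hydroxy(sulfo)methyl it also ends at a limit rather than a number. Compound 4 gives > 100000 nM, which is a limit of the assay. The limit now holds both difluorinated compounds: the limit of > 100000 nM in this assay, at which 2 of the 4 values shown sit.

The step between compound 2 and compound 4 cannot be read, and the true size of the exchange stays hidden on both cores. From the compounds shown here alone, what a cyclohexyl carrying an amine, or a longer chain, would give on that oxygen remains open.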